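A few compounds are considered here, and "the series" means these few. Any claim that something is new, unique, unknown or untested is made for them only; others in the source may bear on it.

Compound 1 `C=C1C(=O)OC[C@@H]1CCOC(=O)Nc1ccc(C)c(C)c1` — 1450 nM
Compound 2 `C=C1C(=O)OC[C@H]1CCOC(=O)Nc1ccc(CCCC)cc1` — 620 nM
Compound 3 `C=C1C(=O)OC[C@@H]1CCOC(=O)Nc1ccc(CC)cc1` — 1260 nM

In a functional assay on RAW264.7 cells (Mus musculus) for inhibition, with a stated time of 30 min (a higher number here means a weaker inhibitor, a lower number a stronger inhibitor), compound 1 gives 1450 nM, the highest of the three numbers. Compound 3 gives 1260 nM in this assay, a gap to compound 1 that lies within the usual scatter. Compound 2 gives 620 nM in this assay, and here the gap to compound 1 lies beyond the scatter. Compound 4 `C=C1C(=O)OC[C@H]1CCOC(=O)Nc1ccc(C)c(C)c1` has not yet been measured. It differs from compound 1 in one point: the two compounds have the same atoms and bonds and differ only in configuration as drawn: 1 of 1 stereo elements differ; a stereocentre at a saturated ring carbon is drawn R in compound 1 and S in compound 4. Among the measured compounds shown here, no pair of measured compounds shows what such a change in configuration does here, so no step is known for it. With that, the step from compound 1 to compound 4 is expected to stay within the scatter, as a 1.1-fold lower number from compound 1 to compound 4 (0.05 log units; within the scatter). For compound 4 the estimate in this assay is 1300 nM, with a range from 500 nM to 3500 nM.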

Compound 4, half-maximal inhibitory concentration: 1090 nM
For compound 4 the middle estimate is 1.2-fold (0.08 log units) above the measured one; the range from low to high includes it.
By their numbers in this assay, from the lowest: compounds 2, 4, 3 and 1 (each within the scatter of the next, the first and the last beyond it).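

Among the compounds shown here, compounds 1 and 4 form the first pair that isolates the stereocentre at a saturated ring carbon, and in this assay inverting it gives a 1.3-fold lower number from compound 1 to compound 4 (0.12 log units; within the scatter). For this substitution, then, the drawn configuration at that position shifts the number by no more than the scatter. The comparison isolates that one stereocentre because nothing else changes: the fact that compounds 1 and 4 differ only in the configuration as drawn

The compounds shown leave open whether configuration matters as little alongside the butyl chain of compound 2. They also leave open how the series would respond to an amine or a carboxylic acid in place of the alkyl groups.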